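Benzyloxyacetyl piperazines: aryl swap on the ring nitrogen

The source may report more compounds than this note shows. Statements on the series, on what has been measured and on what is new or still open speak of the compounds shown alone.

Measured so far:
- compound 1, `O=C(COCc1ccccc1)N1CCN(c2ccccn2)CC1`: 5400 nM
- compound 2, `O=C(COCc1ccccc1)N1CCN(c2ncccc2C(F)(F)F)CC1`: 4300 nM

Working notes. In a functional assay on HEK293 cells for positive allosteric modulation of metabotropic glutamate receptor 5 (Rattus norvegicus), read by fluorescence and calcium flux (on this read-out higher numbers stand for an effect only at larger amounts of compound and lower numbers for an effect already at smaller amounts), compound 1 gives 5400 nM and compound 2 gives 4300 nM. Within the data shown here, the only step recorded between measured compounds is a 1.3-fold lower number from compound 1 to compound 2 (0.10 log units; within the scatter), which corresponds to a trifluoromethyl in place of hydrogen on an aromatic carbon. Among the measured compounds shown here, on the numbers available, compound 1 cannot be set apart from compound 2; the pair lies within the scatter, so the series so far is flat.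

The next compound, compound 3, `COc1ccccc1N1CCN(C(=O)COCc2ccccc2)CC1`, differs from compound 1 by 2-methoxyphenyl in place of pyridin-2-yl on an amine nitrogen in a ring. For the measured compounds named here, no measured step touches this change; the one step on record concerns a substituent on the aryl ring rather than the aryl ring itself, and it was within the scatter. There is therefore no basis in these data for expecting a step beyond the scatter in this assay in either direction.

Compound 3 is accordingly expected near its parent, at 4500 nM, within 1500 nM to 13000 nM. This estimate means a step of a 1.2-fold lower number from compound 1 to compound 3 (0.08 log units; within the scatter), expected to stay within the usual scatter.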

Compound 3, half-maximal effective concentration: 9200 nM
Compound 3: the middle estimate sits 2.0-fold (0.31 log units) below what was measured; low and high end bracket the measured number.
By their numbers in this assay, from the lowest: compounds 2, 1 and 3 (each within the scatter of the next, the first and the last beyond it).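

In this assay, the step to 2-methoxyphenyl in place of pyridin-2-yl on the amine nitrogen in a ring is a 1.7-fold higher number from compound 1 to compound 3 (0.23 log units; within the scatter), so exchanging the aryl ring itself, and not only a substituent on it, also stays within the scatter. The ring nitrogen of pyridin-2-yl can therefore give way to an aromatic ring of carbon only carrying a methoxy group without a step beyond the scatter, and with the entering and leaving groups counted alike for hydrogen-bond acceptors and donors, the series remains flat at this position across the single-place comparisons available. The data offer no measurement that would account for the size of this step.

Still open, going by these compounds, is how the ring exchange and the methoxy group each contribute, which a plain phenyl group on the same nitrogen would separate, since compound 3 carries both changes at once. Also open, on these data alone, is whether any group at this position leaves the scatter, for example a chloro or dimethylamino substituent on the aryl ring, or a saturated ring such as cyclohexyl in place of the aryl ring.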